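Taking the Methoxy Group Off Compound 1

This account rests on a few compounds, and the source may have more. Where it says the series, first, only, none or still open, it means among the compounds named here.

Measured so far in a functional assay on NCI-H522 cells (Homo sapiens) for inhibition, read by colorimetric assay, with a stated time of 3 days; on this read-out higher numbers stand for weaker inhibition and lower numbers for stronger inhibition:
- compound 1 `COc1ccc2sc(NC(=O)CCCCCCNC(=O)C(O)(O)C(F)(F)F)nc2c1`: 3230 nM
- compound 2 `O=C(CCCCCCNC(=O)C(O)(O)C(F)(F)F)Nc1ncc(-c2ccc(O)cc2)s1`: 1900 nM

Among the measured compounds shown here, only these two compounds have numbers so far, so the picture of the series is thin. In this assay compound 1 stands at 3230 nM and compound 2 stands at 1900 nM, and these two values lie within the usual scatter of each other. Neither compound can therefore be ranked above the other.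

Compound 3 `O=C(CCCCCCNC(=O)C(O)(O)C(F)(F)F)Nc1nc2ccccc2s1` is the next to be considered, and it is reached from compound 1 by one change: hydrogen in place of methoxy on an aromatic carbon. In words, hydrogen takes the place of methoxy on an aromatic carbon of the six-membered aromatic ring of carbon only.

For the measured compounds named here, no measured pair shows this change, so the data give no direct guide to its size. The cores of compound 1 and compound 2 differ far more than this, yet compound 2 at 1900 nM stays within the scatter of compound 1 at 3230 nM. No shift beyond the scatter is therefore expected, in either direction.

The expected change is a 1.2-fold lower number from compound 1 to compound 3 (0.06 log units; within the scatter). For compound 3 the estimated value is 2800 nM, with an expected range from 1100 nM to 7000 nM.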

Compound 3, half-maximal inhibitory concentration: 2860 nM
The estimate for compound 3 lay 1.0-fold (0.01 log units) below the measured number, within the range that was stated.
By their numbers in this assay, from the lowest: compounds 2, 3 and 1 (each within the scatter of the next).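

Among the compounds shown here, the step gives the first direct reading at this position. In this assay hydrogen in place of methoxy on an aromatic carbon of the six-membered aromatic ring of carbon only gives a 1.1-fold lower number from compound 1 to compound 3 (0.05 log units; within the scatter) and so stays within the scatter, which the earlier comparison of two different cores could not show for this single change. On the core of compound 1, then, the methoxy group, with its 2 heavy atoms and 1 hydrogen-bond acceptor, can give way to hydrogen at this carbon with no shift that this read-out can separate from repeated measurement, and nothing measured here speaks to why that is so.

The compounds shown leave open whether this carbon tolerates every group equally, as methoxy and hydrogen are the only two seen there, and an amine, a carboxylic acid or a longer ether chain at the same place could still move the number beyond the scatter. They also leave open whether the same exchange of methoxy for hydrogen would stay within the scatter on a different core.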